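Adding a Second Methyl to the Weakest Aryl Ether

This account rests on a few compounds, and the source may have more. Where it says the series, first, only, none or still open, it means among the compounds named here.

Three compounds share one core and differ only in the group on the aromatic ring:
- compound 1, `Cc1ccccc1OCC1=NCCO1`, gives 3.1% in a functional assay on the whole organism for inhibition, with Rattus norvegicus as the target, read by paw edema, with a stated time of 30 min, at a dose of 20 mg/kg by the oral route; on this read-out higher numbers stand for a stronger effect at the one dose given and lower numbers for a weaker effect.
- compound 2, `Clc1ccccc1OCC1=NCCO1`, gives 13.7% in this assay.
- compound 3, `O=[N+]([O-])c1ccccc1OCC1=NCCO1`, gives 20.5% in this assay.

Compound 1 stands lowest of the three. Replacing its methyl by chloro gives a number 10.6 percentage points higher from compound 1 to compound 2 (beyond the scatter), and replacing it by nitro gives a number 17.4 percentage points higher from compound 1 to compound 3 (beyond the scatter); between compound 2 and compound 3 the change is a number 6.8 percentage points higher from compound 2 to compound 3 (within the scatter).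

Compound 4, `Cc1ccc(OCC2=NCCO2)c(C)c1`, keeps the methyl of compound 1 and differs from it in one place: methyl in place of hydrogen on an aromatic carbon. Among the compounds with values here, none of the measured steps adds a group to the ring; each swaps the existing methyl for another group, so none bears directly on this change. With no close guide, the expectation is a step of a number 2.9 percentage points higher from compound 1 to compound 4 (within the scatter) in this assay, not beyond the scatter. Compound 4 is accordingly estimated at 6%, with a range from -6% to 18%.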

Compound 4, a percentage reported as inhibition, in the whole organism at one dose (the size of the read-out at that dose, not a potency): 31.4%
For compound 4 the middle estimate is 25.4 percentage points below the measured one, and the stated range ends below it.
By their numbers in this assay, from the lowest: compound 1; then compounds 2 and 3 (each within the scatter of the next); then compound 4.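

Within the data shown here, compound 1 had so far changed only by swapping its existing methyl, and the new result shows that a ring carbon carrying just hydrogen also matters in this assay: placing a methyl there, meta to a methyl group and para to a group of 7 heavy atoms, gives a number 28.3 percentage points higher from compound 1 to compound 4 (beyond the scatter). The entering group is small, with 1 heavy atom, no ring, no hydrogen-bond donors or acceptors and no net charge, so even a minimal addition at this position can move the read-out beyond the scatter. Nothing available explains why this added methyl has such an effect.

Going by these compounds, it remains open whether an ethyl chain, a methoxy group or an amine at this carbon would give a similar number. The compounds shown also leave open whether adding this methyl to compound 2 or compound 3 would raise their numbers too.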